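Trifluoromethylphenyl Carbamate Following the Difluorophenyl Analogue

The source may hold more compounds than are shown below. What is called first, only, known or untested is meant among the compounds shown, and "the series" means these compounds.

Compound 1 `COc1ccc(NC(=O)Oc2cc(=O)n(CCCO)c3c2CC(C/C=C(\C)CCC=C(C)C)C(C)(C)C3)cc1` gives 0% in a functional assay on PANC-1 cells (Homo sapiens) for inhibition, read by MTT assay, with a stated time of 24 h, tested at 10 uM; a higher number here means more inhibition at the concentration tested (going by the name of the read-out), a lower number less inhibition. Compound 2 `CC(C)=CCC/C(C)=C/CC1Cc2c(OC(=O)Nc3ccc(F)cc3F)cc(=O)n(CCCO)c2CC1(C)C` gives 15.6% and so stands highest of the two numbers, with compound 1 as its nearest neighbour. The step of a number 15.6 percentage points higher from compound 1 to compound 2 (beyond the scatter) is the only measured one, and it concerns a change of the aryl group on the same amide-type nitrogen, so it bears directly on the new compound. Compound 3 `CC(C)=CCC/C(C)=C/CC1Cc2c(OC(=O)Nc3cccc(C(F)(F)F)c3)cc(=O)n(CCCO)c2CC1(C)C` differs from compound 2 by 3-(trifluoromethyl)phenyl in place of 2,4-difluorophenyl on an amide-type nitrogen. Given that one earlier aryl change produced only a modest step, compound 3 is expected to show a step of a number 0.6 percentage points lower from compound 2 to compound 3 (within the scatter), within the scatter, and its estimated value is 15%, ranging from 0% to 35%.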

Compound 3, a percentage reported as inhibition, at one concentration (the size of the read-out at that concentration, not a potency): 6.7%
For compound 3 the middle estimate is 8.3 percentage points above the measured one; low and high end bracket the measured number.
By their numbers in this assay, from the lowest: compounds 1, 3 and 2 (each within the scatter of the next, the first and the last beyond it).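

Moving to 3-(trifluoromethyl)phenyl on the amide-type nitrogen gives a number 8.9 percentage points lower from compound 2 to compound 3 (within the scatter) and, against the 4-methoxyphenyl group, a number 6.7 percentage points higher from compound 1 to compound 3 (within the scatter). In this assay, this aryl change therefore yields a compound that cannot be separated from either earlier compound, although those two lie beyond the scatter of each other. Nothing available accounts for these numbers. The compounds shown leave open whether a phenyl ring bearing an amine or a carboxylic acid, or a longer alkyl chain in place of the aryl group, would raise inhibition beyond the scatter of these three.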